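From 3-methoxyphenyl to 4-methoxyphenyl on compound 2

The source may report more compounds than this note shows. Statements on the series, on what has been measured and on what is new or still open speak of the compounds shown alone.

Of the compounds shown here, two have numbers so far in a functional assay on SW-620 cells (Homo sapiens) for cytotoxicity, read by MTT assay, with a stated time of 72 h; a lower number here means a stronger inhibitor, a higher number a weaker inhibitor. Compound 1 (`COc1ccc(/C=C2\CCC/C(=C\c3ccccc3Br)C2=O)cc1OC`) gives 5300 nM, and compound 2 (`COc1cccc(/C=C2\CCC/C(=C\c3ccc(OC)c(OC)c3)C2=O)c1`) gives 3700 nM. Among the measured compounds shown here, these two values lie within the scatter of each other, so compound 2 stands level with the only other measured compound.

The unmeasured compound 3 (`COc1ccc(/C=C2\CCC/C(=C\c3ccc(OC)c(OC)c3)C2=O)cc1`) has 4-methoxyphenyl in place of 3-methoxyphenyl on a double-bonded chain carbon bound to a double-bonded ring carbon.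

For the measured compounds named here, only one measured step bears on this change, and it lies at the same place: a 1.4-fold lower number from compound 1 to compound 2 (0.16 log units; within the scatter). Going by the values given here, that step exchanges a different group, and no measured pair yet compares these two methoxyphenyl groups directly, so the guidance is thin. With this single step as the guide, no change beyond the scatter is expected in this assay. The expected step is a 1.1-fold lower number from compound 2 to compound 3 (0.02 log units; within the scatter). For compound 3 the estimated value is 3500 nM, with an expected range from 1600 nM to 7500 nM.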

Compound 3, half-maximal inhibitory concentration: 6600 nM
For compound 3 the middle estimate is 1.9-fold (0.28 log units) below the measured one, and the stated range covers the measured number.
By their numbers in this assay, from the lowest: compounds 2, 1 and 3 (each within the scatter of the next).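

The direct comparison of the two methoxyphenyl groups in this assay gives a 1.8-fold higher number from compound 2 to compound 3 (0.25 log units; within the scatter), so 4-methoxyphenyl in place of 3-methoxyphenyl on a double-bonded chain carbon bound to a double-bonded ring carbon has no effect that can be told from the scatter. The further comparison, 4-methoxyphenyl in place of 2-bromophenyl at the same place, gives a 1.2-fold higher number from compound 1 to compound 3 (0.10 log units; within the scatter), so 2-bromophenyl, 3-methoxyphenyl and 4-methoxyphenyl now all read level with one another in these three compounds. No independent measurement is available to account for these numbers.

Still open, on these data alone, is whether any group at this place can move the number in this assay beyond the scatter, for example an amine or a carboxylic acid in place of the methoxy group, or a longer chain such as butoxy. Compound 1, compound 2 and compound 3 also leave open whether the level reading would hold if the rest of the shared core were altered, since only this one place differs among them.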